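Benzyl for pyridin-3-yl on the piperazine nitrogen of the dithiocarbamates

The source may report more compounds than this note shows. Statements on the series, on what has been measured and on what is new or still open speak of the compounds shown alone.

The series shares one core: a benzamide carrying an amine-bearing aryl group, linked through a dithiocarbamate to a cyclic amine. Compound 1 `Nc1ccccc1NC(=O)c1ccc(CSC(=S)N2CCN(c3cccnc3)CC2)cc1` carries pyridin-3-yl on that amine nitrogen; compound 2 `Nc1ccccc1NC(=O)c1ccc(CSC(=S)N2CCc3cc(Cl)ccc32)cc1` carries a fused bicyclic amine with a chlorine substituent. In a functional assay on A-375 cells (Homo sapiens) for antiproliferative activity, read by CCK-8 assay, with a stated time of 72 h, tested at 8 uM (on this read-out lower numbers stand for a weaker effect and higher numbers for a stronger effect at the one concentration tested), compound 1 gives 88.8%, and in this assay compound 2 gives 82.3%. Compound 1 stands at the top of the two numbers shown, but the gap to compound 2 falls within the usual scatter, so the two cannot be separated on this read-out.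

Compound 3 `Nc1ccccc1NC(=O)c1ccc(CSC(=S)N2CCN(Cc3ccccc3)CC2)cc1` has not yet been measured. It differs from compound 1 in one place: benzyl in place of pyridin-3-yl on an amine nitrogen in a ring. No measured pair in the series isolates a change of this kind, so the expectation rests only on the two numbers shown, which both sit high.

Given that, the step of a number 5.8 percentage points lower from compound 1 to compound 3 (within the scatter) is expected to stay within the scatter, with no clear direction. Compound 3 is therefore estimated at 83%, within a range from 66% to 95%, in this assay.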

Compound 3, a percentage reported as inhibition, at one concentration (the size of the read-out at that concentration, not a potency): 29.3%
Compound 3: middle estimate off by 53.7 percentage points, on the high side; the measured number lies below the stated range.
By their numbers in this assay, from the lowest: compound 3; then compounds 2 and 1 (each within the scatter of the next).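

In this assay, the group on the amine nitrogen in the six-membered non-aromatic ring strongly affects the read-out: benzyl in place of pyridin-3-yl gives a number 59.5 percentage points lower from compound 1 to compound 3 (beyond the scatter). For the compounds shown here, the earlier pair offered no single-place step, so this is the first direct sign that the high read-out of compound 1 does not carry over to every group with a six-membered aromatic ring at this position. Nothing given here accounts for the drop.

The change replaces a ring attached directly to the nitrogen by one attached through a carbon link, and it also removes the ring nitrogen, so the compounds shown cannot tell which of these differences goes with the lower number. Phenyl at this position would separate the ring nitrogen from the carbon link when set against compound 1 and compound 3, and pyridin-3-ylmethyl would provide the same test from the other side.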